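Methylsulfanyl in Place of Selenium on the Shared Core

This account rests on a few compounds, and the source may have more. Where it says the series, first, only, none or still open, it means among the compounds named here.

Compound 3 `[SeH]c1nc(NCc2ccccc2)c2ccccc2n1` carries a bare selenium on the shared core. In a functional assay on CCRF-CEM cells (Homo sapiens) for cytotoxicity, read by MTT assay, with a stated time of 72 h (on this read-out higher numbers stand for weaker inhibition of growth and lower numbers for stronger inhibition of growth), compound 3 returns > 100000 nM, which is a limit of the assay and not a number. Its pentyl counterpart, compound 1 `CCCCC[Se]c1nc(NCc2ccccc2)c2ccccc2n1`, gives 72500 nM in this assay, so the step of an at least 1.3-fold higher number from compound 1 to compound 3 (0.13 log units; that floor lies within the scatter) is known only as a floor. Compound 2 `CSc1nc(NCc2ccc([Se]C)cc2)c2ccccc2n1`, which carries methylsulfanyl on the shared core together with a methylselanyl group on the benzyl ring, returns > 100000 nM in this assay; that value is likewise a limit. Compound 4 `CSc1nc(NCc2ccccc2)c2ccccc2n1` differs from compound 3 by a group of 2 heavy atoms (1 carbon, 1 sulfur; no ring) in place of one selenium atom, on an aromatic carbon. Among the measured compounds shown here, only one measured step touches this position, an at least 1.3-fold higher number from compound 1 to compound 3 (0.13 log units; that floor lies within the scatter), and it carries no usable size; beyond that, the record shows (the limit of > 100000 nM in this assay, at which 2 of the 3 values shown sit). With compound 2 already sitting at that limit, compound 4 is expected to remain close to it, and the step that the limit leaves unreadable from compound 3 to compound 4 is expected to be small or unresolved. Compound 4 is therefore estimated at 110000 nM, with a range from 40000 nM to 300000 nM.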

Compound 4, concentration for total growth inhibition: > 100000 nM
Compound 4 gave a limit, no number; the forecaster's own chance of this, stated with the estimate: 65%; the middle value is on the limit's open side.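

In this assay compound 4 gives > 100000 nM, which is a limit of the assay and not a number. Compound 4 holds no selenium at all, so methylsulfanyl on this aromatic carbon leaves the record where bare selenium left it, and the steps linking compound 4 to compound 2 and compound 3 cannot be read. The only step with any reading, an at least 1.3-fold higher number from compound 1 to compound 4 (0.13 log units; that floor lies within the scatter), is a floor without a usable size, and the pentyl compound remains the only one here with a number, so the position now reads: the limit of > 100000 nM in this assay, at which 3 of the 4 values shown sit.

The compounds shown leave open whether pentylsulfanyl in place of methylsulfanyl would return a number in this assay. They also leave open how an amine on this same carbon would read.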